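Swapping a Hydroxyphenyl Arm on a Pyridine Core

The compounds below may be only part of what the source reports. "The series", "measured", "known", "first", "only" and "open" are said of these compounds alone.

The series consists of three measured compounds and one awaiting measurement. Compound 1 `Oc1ccccc1-c1cc(-c2cccs2)cc(-c2ccccc2O)n1` was tested in an assay on isolated protein for inhibition of DNA topoisomerase 1 (Homo sapiens), with a stated time of 30 min, tested at 100 uM (a higher number here means a stronger effect of the compound at the concentration tested, a lower number a weaker effect), and gave 77.2%. Compound 2 `Oc1cccc(-c2cc(-c3cccs3)cc(-c3ccccc3O)n2)c1` differs from compound 1 by 3-hydroxyphenyl in place of 2-hydroxyphenyl on an aromatic carbon, and in this assay compound 2 gives 83.2%, a step of a number 6 percentage points higher from compound 1 to compound 2 (within the scatter). Compound 3 `Oc1ccccc1-c1cc(-c2cccnc2)cc(-c2ccccc2O)n1` carries a different core, the difference from compound 1 being (pyridin-3-yl in place of thiophen-2-yl on an aromatic carbon); in this assay compound 3 gives 66.4%, a step of a number 10.8 percentage points lower from compound 1 to compound 3 (beyond the scatter).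

Compound 4 `Oc1cccc(-c2cc(-c3cccnc3)cc(-c3ccccc3O)n2)c1` has not yet been measured. It differs from compound 3 by 3-hydroxyphenyl in place of 2-hydroxyphenyl on an aromatic carbon. Among the compounds with values here, this is the same kind of change as the one from compound 1 to compound 2, though not the same: in the pair of compound 1 and compound 2 the place is meta to a thiophen-2-yl group, while in the pair of compound 3 and compound 4 it is meta to a pyridin-3-yl group. The earlier instance of this change moved the read-out only within the scatter, so a similar outcome is expected here. Because compound 3 gives 66.4% and the earlier step was a number 6 percentage points higher from compound 1 to compound 2 (within the scatter), compound 4 is expected to show a step of a number 5.6 percentage points higher from compound 3 to compound 4 (within the scatter). For compound 4 in this assay the estimate is 72%, within a range from 58% to 85%.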

Compound 4, a percentage reported as inhibition, at one concentration (the size of the read-out at that concentration, not a potency): 1.9%
Beside the measured number, compound 4's estimate is 70.1 percentage points above it; measured number below the stated range.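

In this assay the exchange of 2-hydroxyphenyl for 3-hydroxyphenyl gives a number 64.5 percentage points lower from compound 3 to compound 4 (beyond the scatter), so on the core carrying pyridin-3-yl it does not behave as it did on the core carrying thiophen-2-yl: the same change on two cores in this assay, a number 6 percentage points higher (within the scatter) from compound 1 to compound 2 and a number 64.5 percentage points lower (beyond the scatter) from compound 3 to compound 4, 70.5 percentage points apart, beyond the scatter of two such steps. The exchange of thiophen-2-yl for pyridin-3-yl is likewise not independent of its partner, giving a number 81.3 percentage points lower from compound 2 to compound 4 (beyond the scatter), a far larger drop than the same exchange produced with two 2-hydroxyphenyl arms in place: the same change on two cores in this assay, a number 10.8 percentage points lower (beyond the scatter) from compound 1 to compound 3 and a number 81.3 percentage points lower (beyond the scatter) from compound 2 to compound 4, 70.5 percentage points apart, beyond the scatter of two such steps. These two comparisons are one result seen from two sides, since both rest on the same four compounds and turn on compound 4; they show that in this series neither change can be carried from one core to another as a fixed increment, but they do not show why the two changes combine this way, or whether the same holds for any other pair of groups.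

The compounds shown leave open whether the sharp loss belongs to this one combination or would also appear with a 4-hydroxyphenyl or methoxyphenyl arm, or with furan-2-yl or pyridin-4-yl in place of pyridin-3-yl. They also leave open how compound 4 behaves at concentrations other than the single one tested.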